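The source may hold more compounds than are shown below. What is called first, only, known or untested is meant among the compounds shown, and "the series" means these compounds.

Measured so far:

Compound 1 `COc1ccc(/C=C/C=C/C(=O)c2ccccc2O)cc1` gives 40% in an in vitro assay on cells for inhibition of Amine oxidase [flavin-containing] A (Homo sapiens), read by Amplex Red, with a stated time of 15 min, tested at 100 uM; a higher number here means more inhibition at the concentration tested (going by the name of the read-out), a lower number less inhibition.
Compound 2 `COc1ccc(/C=C/C(O)=C/C(=O)c2c(O)cccc2OC)cc1OC` gives 40% in this assay.
Compound 3 `COc1ccc(/C=C/C=C/C(=O)c2ccccc2O)cc1OC` gives 40% in this assay.

Compound 3 stands level with compounds 1 and 2 at the digits shown; all three values fall within the scatter of one another, so no ordering can be read from them. Among the compounds with values here, the one step recorded among the measured compounds, no change at the digits printed from compound 1 to compound 3 (within the scatter), shows that adding a methoxy to an aromatic carbon left the read-out unchanged within the scatter.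

Compound 4 `COc1ccc(/C=C/C(O)=C/C(=O)c2ccccc2O)cc1OC` has not yet been measured. It differs from compound 3 by hydroxy in place of hydrogen on a double-bonded chain carbon bound to two double-bonded chain carbons. Within the data shown here, no measured step tests exactly this change. Compound 2 already carries the same hydroxy on its chain together with an additional methoxy on its other ring, and compound 2 gives 40%, the same reading as compound 3. Among the measured compounds shown here, the only recorded step, no change at the digits printed from compound 1 to compound 3 (within the scatter), concerns a different change but also shows no movement. On this basis no step beyond the scatter is expected in this assay; the expected step of no change at the digits printed from compound 3 to compound 4 (within the scatter) is essentially flat. Compound 4 is therefore estimated at 40%, with a range from 25% to 55%.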

Compound 4, a percentage reported as inhibition, at one concentration (the size of the read-out at that concentration, not a potency): "not active" (no number reported)
The entry for compound 4 holds no number; no gap can be computed for the estimate.
By their numbers in this assay, from the lowest: compounds 1, 2 and 3 (each within the scatter of the next).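

Within the data shown here, compound 4 is recorded in this assay as "not active" with no number, so no step from compound 3 to compound 4 can be read. No measurement shown here offers an explanation for this entry. The compounds shown leave open how much the hydroxy on the chain carbon alters inhibition.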